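Replacing the Acyclic Group of Compound 1 with Piperidin-1-ylcarbonyl

This account rests on a few compounds, and the source may have more. Where it says the series, first, only, none or still open, it means among the compounds named here.

Measured compounds:
compound 1 `COc1ccc(-c2nc(/N=C(\N)N(C)C)sc2-c2ccc(OC)cc2)cc1` — 4.8 uM
compound 2 `COc1ccc(-c2nc(/N=C(\N)[N+]3(C)CCCCC3)sc2-c2ccc(OC)cc2)cc1` — 21 uM
compound 3 `COc1ccc(-c2nc(CNC(=O)N3CCOCC3)sc2-c2ccc(OC)cc2)cc1` — 12 uM

In a functional assay (aorta) with Rattus norvegicus as the target (on this read-out lower numbers stand for an effect already at smaller amounts and higher numbers for an effect only at larger amounts of compound), compound 1 gives 4.8 uM, the lowest of the three numbers. The two measured steps away from it both raise the number: a 2.5-fold higher number from compound 1 to compound 3 (0.40 log units; beyond the scatter) and a 4.4-fold higher number from compound 1 to compound 2 (0.64 log units; beyond the scatter). Between the other two compounds the gap is small: a 1.8-fold lower number from compound 2 to compound 3 (0.24 log units; within the scatter).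

Compound 4 `COc1ccc(-c2nc(C(=O)N3CCCCC3)sc2-c2ccc(OC)cc2)cc1` has not yet been measured. It differs from compound 1 in one place: a group of 8 heavy atoms (6 carbon, 1 nitrogen, 1 oxygen; one six-membered non-aromatic ring with 1 hetero atom) in place of a group of 6 heavy atoms (3 carbon, 3 nitrogen; no ring), on an aromatic carbon. Both measured steps bear on this change, since each alters the same position of the shared core, and each gave a modest rise. A rise of similar size is therefore expected, a 3.1-fold higher number from compound 1 to compound 4 (0.49 log units; beyond the scatter), with no reason seen for a larger or opposite step. Compound 4 is estimated at 15 uM, between 6 uM and 40 uM.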

Compound 4, concentration for half-maximal effect: 11 uM
The estimate for compound 4 lay 1.4-fold (0.13 log units) above the measured number; the range from low to high includes it.
By their numbers in this assay, from the lowest: compound 1; then compounds 4, 3 and 2 (each within the scatter of the next).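

In this assay, the step to (piperidin-1-yl)carbonyl, a group with no hydrogen-bond donor, stays modest, at a 2.3-fold higher number from compound 1 to compound 4 (0.36 log units; beyond the scatter). Compound 4 does not separate from the other two ring-bearing compounds, with a 1.1-fold lower number from compound 3 to compound 4 (0.04 log units; within the scatter) and a 1.9-fold lower number from compound 2 to compound 4 (0.28 log units; within the scatter). No measurement is available to explain these steps.

The compounds shown leave open whether the six-membered ring or the carbonyl goes with the step from compound 1. They also leave open how a dimethylaminocarbonyl group or a carboxylic acid would read on this aromatic carbon.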